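Series notes: fluoro for methoxy, growth inhibition estimate

The compounds below may be only part of what the source reports. "The series", "measured", "known", "first", "only" and "open" are said of these compounds alone.

Measured so far:
compound 1, `COc1ccc(-c2ccc(-c3ccc(C(=N)N)cc3)s2)cc1`: 1240 nM
compound 2, `N=C(N)c1ccc(-c2ccc(-c3cc(Cl)cc(Cl)c3)s2)cc1`: "not determined" (no result reported)

Among the measured compounds shown here, compound 1 is the only member of the series with a number in hand. In a functional assay on NCI-H322M cells (Homo sapiens) for inhibition, read by sulforhodamine B assay, with a stated time of 48 h (on this read-out higher numbers stand for weaker inhibition of growth and lower numbers for stronger inhibition of growth), compound 1 gives 1240 nM. Compound 2 carries the same amidine-bearing core but with two chloro groups on the outer ring; for compound 2 this assay returned no value, so nothing can be compared against it. With one number and one blank entry, compound 1 stands alone on the numbers shown, neither strong nor weak relative to anything else in the set.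

Compound 3, `N=C(N)c1ccc(-c2ccc(-c3ccc(F)cc3)s2)cc1`, is the next member to be run in this assay. The change from compound 1 is fluoro in place of methoxy on an aromatic carbon. The substituent exchanged is a single small group at the same place on the outer ring, and the rest of the molecule is untouched.

For the measured compounds named here, no comparison between two measured compounds exists, so there is no internal step to calibrate against. The expectation for this exchange is a step in this assay of no more than the usual scatter, in either direction. On that basis compound 3 is expected to give 1500 nM, within 500 nM to 4500 nM, which means an estimated step of a 1.2-fold higher number from compound 1 to compound 3 (0.08 log units; within the scatter).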

Compound 3, concentration for 50% growth inhibition: 1330 nM
Compound 3: middle estimate off by 1.1-fold (0.05 log units), on the high side; measured number inside the range.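

Among the compounds shown here, the first step between two measured compounds in this assay is a 1.1-fold higher number from compound 1 to compound 3 (0.03 log units; within the scatter), with fluoro in place of methoxy on an aromatic carbon, para to a large group. At this place, therefore, the exchange of methoxy, with 2 heavy atoms and 1 hydrogen-bond acceptor, for fluoro, with 1 heavy atom and 0 hydrogen-bond acceptors, does not separate the two compounds on this growth-inhibition read-out. No measurement among the data shown gives a reason for this result.

Whether any group at this place can move the number beyond the scatter stays open, as the compounds shown include no amine, hydroxyl, carboxylic acid or longer chain such as butoxy there. Compound 2 has no number in this assay, so the compounds shown leave open how the outer ring with two chloro groups reads, and a single step cannot show whether other changes on the shared core would behave the same way.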